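The source may report more compounds than this note shows. Statements on the series, on what has been measured and on what is new or still open speak of the compounds shown alone.

Compound 2 `CCCCCCCCCCCCNC(=O)[C@@H](NC(=O)c1ccccc1)[C@@H](C)O` was tested in a functional assay on A-431 cells (Homo sapiens) for cytotoxicity, read by MTT assay, with a stated time of 48 h (a lower number here means a stronger inhibitor, a higher number a weaker inhibitor), and gave 41200 nM. Among the measured compounds shown here, the only other compound measured is compound 1 `CCCCCCCCNC(=O)[C@@H](NC(=O)c1ccco1)[C@@H](C)O`, which in this assay gave 64500 nM; these two numbers sit within the usual scatter of each other, so neither can be called the stronger. Compound 3 `CCCCCCCCCCCCNC(=O)[C@@H](NC(=O)c1ccco1)[C@@H](C)O` has not been measured yet. It differs from compound 2 in one place: furan-2-yl in place of phenyl on a carbonyl carbon. For the measured compounds named here, no measured pair shows this change alone, and compound 1 carries the same furan-2-yl on a shorter chain without standing apart. The expected step from compound 2 to compound 3 is small, a 1.2-fold higher number from compound 2 to compound 3 (0.08 log units; within the scatter), within the scatter. Compound 3 is therefore estimated at 50000 nM, somewhere between 20000 nM and 130000 nM.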

Compound 3, half-maximal inhibitory concentration: 92400 nM
Compound 3: middle estimate off by 1.8-fold (0.27 log units), on the low side; measured number inside the range.
By their numbers in this assay, from the lowest: compounds 2, 1 and 3 (each within the scatter of the next, the first and the last beyond it).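

In this assay, furan-2-yl in place of phenyl on a carbonyl carbon gives a 2.2-fold higher number from compound 2 to compound 3 (0.35 log units; beyond the scatter), a modest step and the first one beyond the scatter, so this position does respond to the choice of ring. Adding butyl to the chain gives a 1.4-fold higher number from compound 1 to compound 3 (0.16 log units; within the scatter), too small to separate the two compounds. Nothing available explains the ring step.

Going by these compounds, it remains open whether a thiophene ring on this carbonyl carbon would read closer to phenyl or to furan-2-yl. A longer chain is also an open case.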